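Naphthyl amide on the dimethylbenzyl ether series

A few compounds are considered here, and "the series" means these few. Any claim that something is new, unique, unknown or untested is made for them only; others in the source may bear on it.

Going by the values given here, compound 3 `COc1ccc(C(=O)Nc2ccc(N(C)S(=O)(=O)C(F)(F)F)c(OCc3cc(C)ccc3C)c2)cc1OC` gives the highest of the three numbers so far in a functional assay on SK-BR-3 cells (Homo sapiens) for antiproliferative activity, read by MTT assay, with a stated time of 48 h (a higher number here means a weaker inhibitor, a lower number a stronger inhibitor), at 39300 nM. Nearest to it stands compound 2 `Cc1ccc(C)c(COc2cc(NC(=O)c3ccc(Br)cc3)ccc2N(C)S(=O)(=O)C(F)(F)F)c1`, which in this assay gives 36400 nM; the two are within the scatter of each other. Far from both lies compound 1 `COc1ccc(OC)c(COc2cc(NC(=O)c3ccc4ccccc4c3)ccc2N(C)S(=O)(=O)C(F)(F)F)c1`, which in this assay gives 200 nM. Compound 4 `Cc1ccc(C)c(COc2cc(NC(=O)c3ccc4ccccc4c3)ccc2N(C)S(=O)(=O)C(F)(F)F)c1` has not been measured in this assay. It differs from compound 3 as follows: naphthalen-2-yl in place of 3,4-dimethoxyphenyl on a carbonyl carbon.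

Among the compounds with values here, only one measured step bears on the amide aryl group: a 1.1-fold higher number from compound 2 to compound 3 (0.03 log units; within the scatter). That step shows no change beyond the scatter when one aryl on the carbonyl carbon is swapped for another. Within the data shown here, compound 1 also carries the naphthalen-2-yl carbonyl, but it differs from compound 4 in the benzyl ether as well, and no single step separates it from any measured compound, so its low number cannot be assigned to the naphthyl group alone. The expectation for compound 4 therefore leans on the flat step between compound 2 and compound 3, while compound 1 leaves room for a much lower number.

The step from compound 3 to compound 4 is estimated at a 13-fold lower number from compound 3 to compound 4 (1.12 log units; beyond the scatter), a modest move toward a lower number. Compound 4 is thus expected to give about 3000 nM in this assay, with a broad range from 250 nM to 35000 nM.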

Compound 4, half-maximal inhibitory concentration: 41400 nM
Beside the measured number, compound 4's estimate is 14-fold (1.14 log units) below it; the whole stated range lies below it.
By their numbers in this assay, from the lowest: compound 1; then compounds 2, 3 and 4 (each within the scatter of the next).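

With the 2,5-dimethylphenyl ether held fixed, this assay shows no change beyond the scatter when the group on the carbonyl carbon becomes naphthalen-2-yl: the step from 3,4-dimethoxyphenyl is a 1.1-fold higher number from compound 3 to compound 4 (0.02 log units; within the scatter) and the step from 4-bromophenyl is a 1.1-fold higher number from compound 2 to compound 4 (0.06 log units; within the scatter) in the same series. The naphthalen-2-yl amide therefore does not bring a low number on its own in this series. With that amide held fixed, 2,5-dimethylphenyl in place of 2,5-dimethoxyphenyl on the saturated chain carbon bound to an oxygen on an aromatic ring gives a 210-fold higher number from compound 1 to compound 4 (2.32 log units; beyond the scatter) as a large step, so among these compounds the wide gap follows the change in the ether and not the group on the carbonyl carbon.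

The compounds shown leave open whether the 2,5-dimethoxyphenyl ether also gives a low number with 4-bromophenyl or 3,4-dimethoxyphenyl on the carbonyl carbon, and how a benzyl ether with a single methoxy group, a chlorine atom or no substituent would read in this assay against these four. Nothing at hand explains the gap between the two ethers.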